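Chloro to amino on the core of compound 1

The compounds below may be only part of what the source reports. "The series", "measured", "known", "first", "only" and "open" are said of these compounds alone.

Measured so far in an ADME assay on L1210/0 cells (Mus musculus) for cytotoxicity, with a stated time of 48 h; a lower number here means a stronger inhibitor, a higher number a weaker inhibitor:
- compound 1, `Nc1nc(Cl)c2nnn([C@H]3CCCC[C@H]3CO)c2n1`: 95500 nM
- compound 2, `Nc1nc(N)c2ncn([C@H]3CCCC[C@H]3CO)c2n1`: > 200000 nM
- compound 3, `Nc1nc(Cl)c2ncn([C@H]3CCCC[C@H]3CO)c2n1`: > 200000 nM

Within the data shown here, compound 1 gives the only number of the series, 95500 nM in this assay. For compound 2 the value > 200000 nM is a limit of the assay, not a number. For compound 3 the value > 200000 nM is likewise a limit of the assay. The two limits sit at the same point, (the limit of > 200000 nM in this assay, at which 2 of the 3 values shown sit), which is why the step that the two limits leave unreadable from compound 3 to compound 2 cannot be read.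

The change from compound 3 to compound 2 is amino in place of chloro on an aromatic carbon. The cores of compound 1 and compound 3 differ in a way that is not broken down here.

Compound 4, `Nc1nc(N)c2nnn([C@H]3CCCC[C@H]3CO)c2n1`, is not yet measured. Among the measured compounds shown here, it differs from compound 1 by amino in place of chloro on an aromatic carbon, the same change word for word in its place as the one from compound 3 to compound 2. For the measured compounds named here, the only measured example of this change is unreadable, so no direction can be taken from it. What is known is that compound 1 already stands close to the limit at which compound 2 and compound 3 sit, (the limit of > 200000 nM in this assay, at which 2 of the 3 values shown sit). The step from compound 1 to compound 4 is therefore expected to be small or to carry compound 4 into the limit, a 2.1-fold higher number from compound 1 to compound 4 (0.32 log units; beyond the scatter). Compound 4 is expected at 200000 nM in this assay, within 60000 nM to 600000 nM, with a fair chance that only a limit is reported.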

Compound 4, half-maximal inhibitory concentration: > 200000 nM
Compound 4: a limit, no number; the forecaster's own chance of this, stated with the estimate: 60%; the middle value sits exactly at the limit.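

Amino in place of chloro on an aromatic carbon gives an at least 2.0-fold higher number from compound 1 to compound 4 (0.32 log units; beyond the scatter) in this assay, so on the core of compound 1 the change goes toward a higher number, the same direction that stays unconfirmed on the other core. Compound 4 gives > 200000 nM, which is a limit of the assay and not a number. The same change from compound 3 to compound 2 cannot be read, so the series holds no second sized example, and the step's transfer from one core to the other is neither confirmed nor refuted, with the read-out for the whole series bunched up against the same ceiling: the limit of > 200000 nM in this assay, at which 3 of the 4 values shown sit.

Open, from the compounds shown here alone, is how a methoxy group or a thiol in place of chloro on the core of compound 1 would read in this assay, and whether either would give a lower number than compound 1 does. Also open, going by these compounds, is whether a carboxylic acid in place of the hydroxymethyl group would bring compound 4 or compound 2 down to a readable number.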